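Swapping 2,6-dichlorophenyl for 2,4-dichlorophenyl in a weak series

A few compounds are considered here, and "the series" means these few. Any claim that something is new, unique, unknown or untested is made for them only; others in the source may bear on it.

In a functional assay on MDA-MB-231 cells (Homo sapiens) for antiproliferative activity, read by MTT assay, with a stated time of 24 h (a lower number here means a stronger inhibitor, a higher number a weaker inhibitor), compound 1 `CC(C)(C)c1ccc(C(CC(=O)O)NC(=O)c2ccc(F)cc2)cc1` gives 87600 nM. Compound 2 `COc1ccccc1C(=O)NC(CC(=O)O)c1ccc(C(C)(C)C)cc1` gives > 100000 nM, which is a limit of the assay and not a number. Compound 3 `CC(C)(C)c1ccc(C(CC(=O)O)NC(=O)c2c(Cl)cccc2Cl)cc1` gives > 100000 nM, also only a limit, and so it stands at the limit of > 100000 nM in this assay, at which 2 of the 3 values shown sit.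

Compound 4 `CC(C)(C)c1ccc(C(CC(=O)O)NC(=O)c2ccc(Cl)cc2Cl)cc1` carries 2,4-dichlorophenyl in place of 2,6-dichlorophenyl on a carbonyl carbon, with the same atoms joined differently: 2,4-dichlorophenyl in place of 2,6-dichlorophenyl on a carbonyl carbon.

The measured steps that bear on this change the same group on that carbonyl carbon. They show an at least 1.1-fold higher number from compound 1 to compound 2 (0.05 log units; that floor lies within the scatter) and an at least 1.1-fold higher number from compound 1 to compound 3 (0.05 log units; that floor lies within the scatter). The remaining pair gives a step that the two limits leave unreadable from compound 2 to compound 3. None of them therefore offers a readable size or a direction for the new change.

The expected step is an at least 1.0-fold lower number from compound 3 to compound 4 (0.02 log units; that floor lies within the scatter), with none expected beyond the scatter. Compound 4 is estimated at 95000 nM, with an expected range from 50000 nM to 180000 nM, and it may well report only a limit.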

Compound 4, half-maximal inhibitory concentration: 67800 nM
Beside the measured number, compound 4's estimate is 1.4-fold (0.15 log units) above it; the range from low to high includes it.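

In this assay, 2,4-dichlorophenyl on the carbonyl carbon gives a readable number where 2,6-dichlorophenyl gave only a limit of the assay, yet the result is an at least 1.4-fold lower number from compound 3 to compound 4 (0.16 log units; that floor lies within the scatter), so no real gain can be claimed. The comparison with 2-methoxyphenyl, also made against a limit, is no firmer, at an at least 1.4-fold lower number from compound 2 to compound 4 (0.16 log units; that floor lies within the scatter). For the compounds shown here, the only comparison between two true numbers, with 4-fluorophenyl, gives a 1.3-fold lower number from compound 1 to compound 4 (0.11 log units; within the scatter), so these two aromatic groups cannot be told apart here.

As far as these compounds go, how far compound 3 truly lies from compound 4 stays unknown, because compound 3 gives only a limit: the limit of > 100000 nM in this assay, at which 2 of the 4 values shown sit. Also open, from the compounds shown here alone, is whether an amine or a longer chain in place of the dichlorophenyl group would move the number beyond the scatter.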